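The source may report more compounds than this note shows. Statements on the series, on what has been measured and on what is new or still open speak of the compounds shown alone.

Measured so far in a functional assay on MCF7 cells (Homo sapiens) for cytotoxicity, read by MTT assay, with a stated time of 96 h; a lower number here means a stronger inhibitor, a higher number a weaker inhibitor:
compound 1 `COc1cc(C(=O)c2cn(-c3ccccc3C)cc2-c2ccccc2)cc(OC)c1OC`: 2200 nM
compound 2 `COc1ccccc1-n1cc(C(=O)c2cc(OC)c(OC)c(OC)c2)c(-c2ccccc2)c1`: 150 nM
compound 3 `COc1cc(C(=O)c2cn(-c3cccc([N+](=O)[O-])c3)cc2-c2ccccc2)cc(OC)c1OC`: 550 nM

Compound 3 stands second highest of the three numbers, with a 3.7-fold higher number from compound 2 to compound 3 (0.56 log units; beyond the scatter) and a 4.0-fold lower number from compound 1 to compound 3 (0.60 log units; beyond the scatter) as its links to the other two. The next structure is compound 4 `COc1cc(C(=O)c2cn(-c3ccc([N+](=O)[O-])cc3)cc2-c2ccccc2)cc(OC)c1OC`, and the change is 4-nitrophenyl in place of 3-nitrophenyl on an aromatic nitrogen. The shared core is untouched.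

For the measured compounds named here, no measured step moves a nitro group, so the evidence is indirect. All three steps change the group on this same nitrogen, and the largest, a 15-fold lower number from compound 1 to compound 2 (1.17 log units; beyond the scatter), shows that a small edit there can count in this assay. The two steps involving the 3-nitrophenyl group are modest. A step of that size in either direction is therefore possible, but the data favour neither direction, so no shift beyond the scatter is expected. The estimated step is a 1.1-fold lower number from compound 3 to compound 4 (0.04 log units; within the scatter). The expected value for compound 4 is 500 nM, with an estimated range of 160 nM to 1600 nM.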

Compound 4, half-maximal inhibitory concentration: 4000 nM
Beside the measured number, compound 4's estimate is 8.0-fold (0.90 log units) below it, outside the stated range (above it).
By their numbers in this assay, from the lowest: compound 2; then compound 3; then compounds 1 and 4 (each within the scatter of the next).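

Moving the nitro group on the aryl ring attached to the aromatic nitrogen, with the atoms unchanged, is enough to separate two compounds in this assay (a 7.3-fold higher number from compound 3 to compound 4 (0.86 log units; beyond the scatter)), so the result depends on where the nitro group sits and not only on its presence. Against the 2-methylphenyl group, the 4-nitrophenyl group shows no separation (a 1.8-fold higher number from compound 1 to compound 4 (0.26 log units; within the scatter)), while against the 2-methoxyphenyl group it gives the widest gap in the series (a 27-fold higher number from compound 2 to compound 4 (1.43 log units; beyond the scatter)). Nothing measured here accounts for these differences.

Still open, from the compounds shown here alone, is whether position matters as much for the methoxy group, which 3-methoxyphenyl and 4-methoxyphenyl on this nitrogen would test. Also open, going by these compounds, is whether the 4-nitrophenyl result is specific to nitro, which 4-aminophenyl or 4-carboxyphenyl would test.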